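A few compounds are considered here, and "the series" means these few. Any claim that something is new, unique, unknown or untested is made for them only; others in the source may bear on it.

Working notes on the series. Of the compounds shown here, three with a shared core have been measured: compound 1 `O=S(=O)(c1cccc(Br)c1)c1cn(C2CCNC2)c2ncccc12`, compound 2 `O=S(=O)(c1ccccc1)c1cn(C2CCCNC2)c2ncccc12` and compound 3 `O=S(=O)(c1cccc(Cl)c1)c1cn(C2CCCNC2)c2ncccc12`. In a functional assay on HeLa cells for agonist activity at 5-hydroxytryptamine receptor 6 (Homo sapiens), read by cAMP accumulation and immunoassay (on this read-out lower numbers stand for an effect already at smaller amounts and higher numbers for an effect only at larger amounts of compound), compound 1 gives 35 nM, compound 2 gives 47 nM and compound 3 gives 30 nM. Compound 3 carries the smallest of the three numbers, but its gap to compound 1 and its gap to compound 2 are each within the scatter, so the three are not separated. Going by the values given here, the single one-point step among them, a chloro entering in place of hydrogen, reads a 1.6-fold lower number from compound 2 to compound 3 (0.19 log units; within the scatter) and is within the scatter.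

Compound 4 `O=S(=O)(c1cccc(Br)c1)c1cn(C2CCCNC2)c2ncccc12` is not yet measured. It differs from compound 3 by bromo in place of chloro on an aromatic carbon. Among the compounds with values here, no measured pair shows a chloro-to-bromo exchange directly. Compound 1, the bromo-bearing member with a different amine ring, gives 35 nM, close to compound 3. With the halogen entry already within the scatter and the bromo analogue compound 1 close by, no step beyond the scatter is expected in this assay. Compound 4 is therefore estimated at 30 nM, with a range from 15 nM to 60 nM, an expected step of no change at the digits printed from compound 3 to compound 4 (within the scatter) that stays within the scatter.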

Compound 4, half-maximal effective concentration: 72 nM
Compound 4: middle estimate off by 2.4-fold (0.38 log units), on the low side, outside the stated range (above it).
By their numbers in this assay, from the lowest: compounds 3, 1, 2 and 4 (each within the scatter of the next, the first and the last beyond it).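

In this assay, going by these compounds alone, the exchange of 3-chlorophenyl for 3-bromophenyl gives the only step between halogens at this place, and it passes the scatter: a 2.4-fold higher number from compound 3 to compound 4 (0.38 log units; beyond the scatter). Against hydrogen the bromo entry does not separate, with a 1.5-fold higher number from compound 2 to compound 4 (0.19 log units; within the scatter), so on the piperidin-3-yl compounds the gap appears between the two halogens and not between either halogen and hydrogen. With bromo held fixed, the amine ring also counts, since piperidin-3-yl in place of pyrrolidin-3-yl reads a 2.1-fold higher number from compound 1 to compound 4 (0.31 log units; beyond the scatter), and the number of compound 1 therefore did not carry over to the other ring.

Nothing at hand accounts for these steps. The compounds shown leave open how a 3-chlorophenyl group reads on the pyrrolidin-3-yl ring, and how a fluoro or a methoxy group reads at the same place.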